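Hydroxymethyl to trifluoromethyl in compound 3

A few compounds are considered here, and "the series" means these few. Any claim that something is new, unique, unknown or untested is made for them only; others in the source may bear on it.

Compound 1 `CCCn1nc(C(=O)N[C@H]2COc3ccccc3N(C)C2=S)nc1Cc1ccccc1` gives > 100000 nM as a limit
Compound 2 `CN1C(=S)[C@@H](NC(=O)c2nc(Cc3ccccc3)n(CCCO)n2)COc2ccccc21` gives > 100000 nM as a limit

Both readings come from a toxicity assay on HT-29 cells (Homo sapiens) for cytotoxicity (on this read-out higher numbers stand for lower toxicity in this test and lower numbers for higher toxicity in this test), and neither is a true number. In this assay compound 2 gives > 100000 nM as a limit of the assay. Compound 2 therefore stands with compound 1 under the limit of > 100000 nM in this assay, at which 2 of the 2 values shown sit, and the two cannot be ranked.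

Compound 3 `CN1C(=S)[C@@H](NC(=O)c2nc(Cc3ccccc3)n(CCC(F)(F)F)n2)COc2ccccc21` keeps the shared core, with trifluoromethyl in place of hydroxymethyl on a saturated chain carbon, two bonds along the chain from an aromatic nitrogen. For the measured compounds named here, only one measured step touches this chain (a step that the two limits leave unreadable from compound 1 to compound 2). It puts hydroxy in place of hydrogen and offers no size to carry over.

Given the limit of > 100000 nM in this assay, at which 2 of the 2 values shown sit, as the only guide, no step beyond the scatter is expected in this assay and no direction can be argued. The estimated change is small (a number no higher from compound 2 to compound 3 (the limit leaves the size open)). For compound 3 the expected value is 100000 nM within an estimated range of 40000 nM to 150000 nM and it will probably be reported only as a limit.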

Compound 3, half-maximal cytotoxic concentration: > 100000 nM
Compound 3 gave a limit, no number (the forecaster's own chance of this, stated with the estimate: 85%); the middle value lies on the limit itself.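

No step can be read between compound 1, compound 2 and compound 3, since all three results are limits rather than numbers: the limit of > 100000 nM in this assay, at which 3 of the 3 values shown sit.

The compounds shown leave open at what concentration any of them would become toxic to these cells, and whether 3-hydroxypropyl and 3,3,3-trifluoropropyl differ at all in this test.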